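The source may hold more compounds than are shown below. What is called first, only, known or untested is meant among the compounds shown, and "the series" means these compounds.

Compound 1 `CCNC(=O)Nc1sc2ccccc2c1C(=O)N1CCN(C2CCN(C(=O)CC)CC2)CC1` carries a propanoyl group on the ring nitrogen of its core. In a functional assay on HepG2 cells (Homo sapiens) for inhibition, read by scintillation counting, with a stated time of 2 h (a higher number here means a weaker inhibitor, a lower number a stronger inhibitor), compound 1 is recorded as "not determined" (no result reported), so no number places it. Compound 2 `CCNC(=O)Nc1sc2ccccc2c1C(=O)N1CCN(C2CCN(C(=O)CC(C)C)CC2)CC1` likewise shows "not determined" (no result reported) in this assay. Compound 3 `CCNC(=O)Nc1sc2ccccc2c1C(=O)N1CCN(C2CCN(C(=O)C3CCCC3)CC2)CC1` gives 309 nM in this assay, the only figure available for the series. Compound 4 `CCNC(=O)Nc1sc2ccccc2c1C(=O)N1CCN(C2CCN(C(=O)C(C)(C)C)CC2)CC1` differs from compound 1 by tert-butyl in place of ethyl on a carbonyl carbon. Among the measured compounds shown here, with no number for compound 1, neither the size nor the direction of the step to compound 4 can be drawn from the data; the only anchor is compound 3, whose value in this assay is 309 nM. Compound 4 is therefore expected to give about 350 nM in this assay, within an estimated range of 100 nM to 1500 nM.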

Compound 4, half-maximal inhibitory concentration: 450 nM
Estimate against measurement, compound 4: 1.3-fold (0.11 log units) below; the range from low to high includes it.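

In this assay tert-butyl in place of cyclopentyl on a carbonyl carbon gives a 1.5-fold higher number from compound 3 to compound 4 (0.16 log units; within the scatter) and so does not separate these two groups at this position, although only cyclopentyl has a ring. The steps that start from compound 1 or compound 2 cannot be read. Nothing measured here offers an explanation for this result.

Going by these compounds, whether the ethyl of compound 1 would sit with these two groups therefore stays open. So does the outcome of a carboxylic acid or an amine carried on the chain at this carbonyl carbon.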